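Adding a methoxy group to compound 1

The compounds below may be only part of what the source reports. "The series", "measured", "known", "first", "only" and "open" are said of these compounds alone.

compound 1 `COc1ccc(O)c(C(=O)/C=C/c2csc3ccccc23)c1`: 580 nM
compound 2 `CCOc1ccc(O)c(C(=O)/C=C/c2csc3ccccc23)c1`: 5400 nM
compound 3 `COc1ccc(OC)c(C(=O)/C=C/c2csc3ccccc23)c1`: 4100 nM

In a functional assay on A549 cells (Homo sapiens) for antiproliferative activity, read by sulforhodamine B assay, with a stated time of 72 h (a lower number here means a stronger inhibitor, a higher number a weaker inhibitor), compound 1 gives 580 nM, the lowest of the three numbers, which makes it the strongest inhibitor of this small set. The next compound to consider, compound 4 `COc1cc(O)c(C(=O)/C=C/c2csc3ccccc23)cc1OC`, has not yet been measured. It keeps the core of compound 1 and carries one change: methoxy in place of hydrogen on an aromatic carbon.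

Two measured steps offer some guidance. Adding a methyl to the chain of the methoxy group gives a 9.3-fold higher number from compound 1 to compound 2 (0.97 log units; beyond the scatter). Adding a methyl on the oxygen of the hydroxy group gives a 7.1-fold higher number from compound 1 to compound 3 (0.85 log units; beyond the scatter). Both are modest steps in the same direction, and both lie beyond the usual scatter. Within the data shown here, neither, however, touches the aromatic carbon that changes in compound 4, and the data hold no example of a substitution at that carbon. They are therefore indirect evidence, and two cases make no rule.

A weaker compound is still the more likely outcome, probably by less than either measured step, though little or no change cannot be ruled out. The expected change is a 2.6-fold higher number from compound 1 to compound 4 (0.41 log units; beyond the scatter). For compound 4 the estimated value is 1500 nM, with an expected range of 350 nM to 6000 nM.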

Compound 4, half-maximal inhibitory concentration: 450 nM
Estimate against measurement, compound 4: 3.3-fold (0.52 log units) above, and the stated range covers the measured number.
By their numbers in this assay, from the lowest: compounds 4 and 1 (each within the scatter of the next); then compounds 3 and 2 (each within the scatter of the next).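

In this assay, a methoxy group in place of hydrogen on this aromatic carbon, ortho to a methoxy group and meta to a hydroxy group, gives a 1.3-fold lower number from compound 1 to compound 4 (0.11 log units; within the scatter) and so leaves the number effectively unchanged. That sets this position apart from the two existing oxygen substituents, where adding a single methyl gave a 9.3-fold higher number from compound 1 to compound 2 (0.97 log units; beyond the scatter) on the methoxy group and a 7.1-fold higher number from compound 1 to compound 3 (0.85 log units; beyond the scatter) on the hydroxy group, so in this small set, added bulk does not cost activity everywhere on the ring. Nothing available explains why this carbon accepts the new group while the two neighbouring substituents on the same ring respond so differently.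

One methoxy group cannot show how much freedom this carbon really offers, and an amine, a carboxylic acid or a longer chain such as butoxy could give a quite different number there. As far as these compounds go, it also remains open whether the steps seen for compound 2 and compound 3 would be of similar size on the core of compound 4, which carries the extra methoxy group.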